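The source may hold more compounds than are shown below. What is called first, only, known or untested is meant among the compounds shown, and "the series" means these compounds.

The compounds measured so far, all in a functional assay on CHO-K1 cells with Glucose-dependent insulinotropic receptor (Homo sapiens) as the target, read by a luciferase reporter, with a stated time of 5 h; a lower number here means a smaller maximal response, a higher number a larger maximal response:

compound 1 `CC(C)(C)OC(=O)N1CCC(Oc2cccc3c2ccn3-c2ccc(S(C)(=O)=O)cc2)CC1`, giving 28%
compound 2 `CC(C)(C)OC(=O)N1CCC(Oc2cccc3c2CCN3c2ccc(S(C)(=O)=O)cc2)CC1`, giving 92%
compound 3 `CCOC(=O)N1CCC(Oc2ncnc3c2CCN3c2ccc(S(C)(=O)=O)cc2F)CC1`, giving 135%

Among these three, compound 3 stands highest. Its nearest neighbour is compound 2, whose number is lower by an amount beyond the usual scatter, and the gap to compound 1 is wider still. So compound 3 gives the largest maximal response of the set, with a clear margin to both others.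

The step to compound 4 `CS(=O)(=O)c1ccc(N2CCc3c(OC4CCN(C(=S)Sc5ccccc5)CC4)ncnc32)c(F)c1` keeps everything else of compound 3 and changes one group: a group of 9 heavy atoms (7 carbon, 2 sulfur; one six-membered aromatic ring of carbon only) in place of a group of 5 heavy atoms (3 carbon, 2 oxygen; no ring), on an amine nitrogen in a ring

Going by the values given here, only three compounds are known, none of them differing from another in a single place, so there is no measured step of this kind to lean on. What the three do show is that the ring-bound carbamate has been carried unchanged through compounds 1 to 3 while the rest of the molecule varied, so its contribution to the response cannot be read from them. The entering group brings an aromatic ring and two sulfur atoms where the leaving group had none of the one and two oxygens instead of the other; a change this large at that nitrogen could go either way, and a downward step that reaches beyond the scatter seems somewhat more likely than a gain.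

In this assay compound 4 is expected to give 110%, within a range of 60% to 150%. The expected step of a number 25 percentage points lower from compound 3 to compound 4 (beyond the scatter) is therefore a moderate loss, though one the scatter could partly swallow.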

Compound 4, largest response reached (reported as percent of maximum), in percent of the reference or control that the assay uses: 103%
For compound 4 the middle estimate is 7 percentage points above the measured one; low and high end bracket the measured number.
By their numbers in this assay, from the lowest: compound 1; then compound 2; then compound 4; then compound 3.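

Swapping ethoxycarbonyl for the larger group holding two sulfur atoms and a six-membered aromatic ring of carbon only, on the amine nitrogen in the six-membered non-aromatic ring, gives a number 32 percentage points lower from compound 3 to compound 4 (beyond the scatter) in this assay. Going by these compounds alone, this shows that the group on this nitrogen, which stood as a carbamate in all the earlier compounds, does affect the maximal response, yet the change does not abolish it: compound 4 still reaches 103% in this assay. Nothing measured here says why the response falls.

This single step changes the size of the group, adds the aromatic ring and puts sulfur in place of oxygen all at once, so the compounds shown cannot tell which of these parts goes with the lower number. Going by these compounds, a group that keeps the phenyl ring but has oxygen in place of both sulfur atoms, or a sulfur-bearing group with an ethyl chain and no ring, would separate these parts, and how a simple amide or a free amine at this nitrogen would behave remains open too.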